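From Compound 3 to Compound 4: An Expected Step

The source may hold more compounds than are shown below. What is called first, only, known or untested is meant among the compounds shown, and "the series" means these compounds.

Compound 1, `O=C(O)[C@@H]1CCCN1C(=O)CN(c1nc(Cl)nc2[nH]cnc12)C1CC1`, gives 7.29%.
Compound 2, `CC[C@H](C)[C@H](NC(=O)CN(c1ncnc2c1ncn2C1CCCCO1)C1CC1)C(=O)OCc1ccccc1`, gives 16.4%.
Compound 3, `CC(C)C[C@H](NC(=O)CN(c1nc(Cl)nc2[nH]cnc12)C1CC1)C(=O)OCc1ccccc1`, gives 5.26%.

These three numbers all come from a functional assay on the whole organism (Tail, strain ICR) with Mus musculus as the target, in the tail flick test, with a stated time of 150 min, at a dose of 25 umol/kg by the oral route; a lower number here means a weaker effect, a higher number a stronger effect of the compound at the dose given. Within them, compound 3 stands lowest, though the nearest number, that of compound 1, lies within the scatter of it, so no order between compound 3 and compound 1 can be read from the data. Compound 2 lies beyond the scatter above compound 3, and it is the only one of the three that does. The whole set sits in a low region of the read-out.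

Compound 4, `NC(=O)CC[C@H](NC(=O)CN(c1nc(Cl)nc2[nH]cnc12)C1CC1)C(=O)OCc1ccccc1`, differs from compound 3 in one place: carbamoylmethyl in place of isopropyl on a saturated chain carbon, two bonds along the chain from an amide-type nitrogen and a carbonyl carbon.

No step between two measured compounds that differ in one place has been shown, so there is no measured reference for a change of this kind. The expectation therefore rests on where the measured numbers lie. The step from compound 3 to compound 4 is expected to be small, a number 1.7 percentage points higher from compound 3 to compound 4 (within the scatter), and not beyond the scatter in either direction. Compound 4 is accordingly expected to give 7% in this assay, with a range from 0% to 18%.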

Compound 4, a percentage reported as activity, at one dose (the size of the read-out at that dose, not a potency): 31.1%
The estimate for compound 4 lay 24.1 percentage points below the measured number; measured number outside the range, above it.
By their numbers in this assay, from the lowest: compounds 3, 1 and 2 (each within the scatter of the next, the first and the last beyond it); then compound 4.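

In this assay, among these compounds, the change of isopropyl to carbamoylmethyl on a saturated chain carbon, two bonds along the chain from an amide-type nitrogen and a carbonyl carbon, gives a number 25.8 percentage points higher from compound 3 to compound 4 (beyond the scatter), and this is the first step that can be read between compounds differing in one place. It shows that the read-out at this dose responds to the group at this position, even with the rest of the compound held constant, and that an entering group with a hydrogen-bond donor and a hydrogen-bond acceptor can go with a higher number than a leaving group with neither. Nothing measured here bears on what lies behind this step.

From the compounds shown here alone, this single pair cannot separate the contribution of the terminal amide from that of the chain that carries it, so it remains open whether a carboxylic acid, an amine or a hydroxyl group at the same place, or a longer chain ending in the same amide, would give a similar number. Going by these compounds, it also remains open whether the same change would have a similar effect on the core of compound 2, or with the proline-type portion of compound 1.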